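From cyclobutyl to isobutyl on the amide nitrogen

The compounds below may be only part of what the source reports. "The series", "measured", "known", "first", "only" and "open" are said of these compounds alone.

In a functional assay on A549 cells (Homo sapiens) for inhibition, read by sulforhodamine B assay, with a stated time of 72 h (on this read-out higher numbers stand for weaker inhibition and lower numbers for stronger inhibition), compound 1 `CC1CN(C(=O)c2c(N)sc(-c3ccc(Cl)cc3)c2-c2ccc(Cl)cc2)CCN1` gives 4930 nM and compound 2 `Nc1sc(-c2ccc(Cl)cc2)c(-c2ccc(Cl)cc2)c1C(=O)NC1CCC1` gives 12500 nM as the higher of the two numbers available, a gap beyond the scatter. For compound 3 `CCN(CC)CCNC(=O)Nc1sc(-c2ccc(Cl)cc2)c(-c2ccc(Cl)cc2)c1C(=O)NC1CC1` the entry reads "not determined" (no result reported) and offers no comparison.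

The change to compound 4 `CC(C)CNC(=O)c1c(N)sc(-c2ccc(Cl)cc2)c1-c1ccc(Cl)cc1` is isobutyl in place of cyclobutyl on an amide-type nitrogen and reads in words as isobutyl in place of cyclobutyl on an amide-type nitrogen. Going by the values given here, no measured pair compares these two groups directly. Among the compounds with values here, the one measured step, cyclobutylamino in place of 3-methylpiperazin-1-yl on a carbonyl carbon, bears on this change only indirectly. Within the data shown here, with that modest step a 2.5-fold higher number from compound 1 to compound 2 (0.40 log units; beyond the scatter) as the sole guide, the shift in this assay is expected to stay within the scatter, with neither direction favoured. The estimated move a 1.1-fold lower number from compound 2 to compound 4 (0.06 log units; within the scatter) is therefore small, and nothing beyond the scatter is expected. For compound 4 the estimated value is 11000 nM with an expected range from 5000 nM to 25000 nM on this read-out.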

Compound 4, half-maximal inhibitory concentration: 21000 nM
Compound 4: middle estimate off by 1.9-fold (0.28 log units), on the low side; measured number inside the range.
By their numbers in this assay, from the lowest: compound 1; then compounds 2 and 4 (each within the scatter of the next).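

In this assay, isobutyl in place of cyclobutyl on an amide-type nitrogen gives a 1.7-fold higher number from compound 2 to compound 4 (0.23 log units; within the scatter), so at this position the open chain and the four-membered ring, each of 4 heavy atoms, cannot be told apart. The other step here is a 4.3-fold higher number from compound 1 to compound 4 (0.63 log units; beyond the scatter), which runs the same way as a 2.5-fold higher number from compound 1 to compound 2 (0.40 log units; beyond the scatter) and leaves compound 1 with the lowest number of the three, whichever of these two carbon groups stands on the amide nitrogen. The data offer no measurement that accounts for the gap between compound 1 and the other two compounds.

Still open, from the compounds shown here alone, is whether the gap to compound 1 follows the 3-methylpiperazin-1-yl group as a whole or only part of it, which a piperazin-1-yl group without the methyl, or a morpholine, on the same carbonyl carbon could help to separate. Also open, going by these compounds, is how this position responds to a longer chain such as n-hexyl, or to a chain ending in a primary amine or a carboxylic acid, since the compounds with numbers carry only small carbon groups or the 3-methylpiperazin-1-yl group here.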